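Methoxy for Hydroxymethyl on a Shared Thiazolopyrimidine-Free Core

The compounds below may be only part of what the source reports. "The series", "measured", "known", "first", "only" and "open" are said of these compounds alone.

Compound 1, `COc1ccc(-c2nc(N)c3nc(-c4ccccc4)sc3n2)cc1`: > 30000 nM
Compound 2, `Nc1nc(-c2ccccc2)nc2sc(-c3ccco3)nc12`: > 30000 nM
Compound 3, `Nc1nc(-c2ccc(CO)cc2)nc2sc(-c3ccco3)nc12`: > 30000 nM

Three compounds built on a shared core were tested in a functional assay on CHO cells for antagonist activity at adenosine receptor A2b (Homo sapiens), read by cAMP accumulation, with a stated time of 10 min; on this read-out lower numbers stand for stronger inhibition and higher numbers for weaker inhibition. None of the three gave a number: each value is a limit of the assay, as the limit of > 30000 nM in this assay, at which 3 of the 3 values shown sit, records. Compound 3 therefore stands at the limit, with no measurable activity, and the same is true of compound 1 and compound 2.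

Only one measured step joins two of these compounds in one place. The step that the two limits leave unreadable from compound 2 to compound 3 cannot be read, since both ends sit at the limit.

Compound 4, `COc1ccc(-c2nc(N)c3nc(-c4ccco4)sc3n2)cc1`, differs from compound 3 in one place: methoxy in place of hydroxymethyl on an aromatic carbon. Compound 1 already carries this methoxy group on a furan-free core and also sits at the limit. Going by the values given here, no measured step shows any readable change on this core, so no step beyond the scatter is expected for compound 4.

Compound 4 is expected to remain without measurable activity, with a step that the limit leaves unreadable from compound 3 to compound 4 from compound 3 and an estimate of 40000 nM (range 10000 nM to 150000 nM).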

Compound 4, half-maximal inhibitory concentration: > 30000 nM
Compound 4 ended at the assay's limit; the forecaster's own chance of this, stated with the estimate: 85%; the middle value lies beyond the limit too.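

Going by these compounds alone, no step to compound 4 from compound 1, compound 2 or compound 3 can be read, since all four compounds end at a limit and not at a number: the limit of > 30000 nM in this assay, at which 4 of the 4 values shown sit.

The compounds shown leave open whether any single change on the shared core would give a measurable value in this assay at all.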